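The compounds below may be only part of what the source reports. "The series", "measured", "known", "first", "only" and "open" are said of these compounds alone.

Among the measured compounds shown here, compound 3 `O=C(O)CCCC(=O)N1CCC(NS(=O)(=O)c2cc(S(=O)(=O)c3ccccc3)ccc2C(F)(F)F)CC1` stands second highest of the three numbers so far in an assay on U2OS cells for inhibition of secreted frizzled-related protein 1 (Homo sapiens), read by a luciferase reporter, with a stated time of 18 h (on this read-out lower numbers stand for an effect already at smaller amounts and higher numbers for an effect only at larger amounts of compound), where compound 3 gives 570 nM. Its nearest neighbour is compound 1 `O=C(c1ccc(C(F)(F)F)cc1)N1CCC(NS(=O)(=O)c2cc(S(=O)(=O)c3ccccc3)ccc2C(F)(F)F)CC1`, which in this assay gives 970 nM; the step of a 1.7-fold lower number from compound 1 to compound 3 (0.23 log units; within the scatter) lies within the scatter. The furthest is compound 2 `N#Cc1cccc(S(=O)(=O)N2CCC(NS(=O)(=O)c3cc(S(=O)(=O)c4ccccc4)ccc3C(F)(F)F)CC2)c1`, which in this assay gives 170 nM; the step of a 3.4-fold higher number from compound 2 to compound 3 (0.53 log units; beyond the scatter) lies beyond it, as does the step of a 5.7-fold lower number from compound 1 to compound 2 (0.76 log units; beyond the scatter).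

Compound 4 `O=C(C1CCNCC1)N1CCC(NS(=O)(=O)c2cc(S(=O)(=O)c3ccccc3)ccc2C(F)(F)F)CC1` differs from compound 3 in one place: piperidin-4-yl in place of 3-carboxypropyl on a carbonyl carbon. For the measured compounds named here, no measured step exchanges one group on that carbonyl carbon for a ring of this kind. Going by the values given here, the only step at that position, a 1.7-fold lower number from compound 1 to compound 3 (0.23 log units; within the scatter), was within the scatter, and the larger movements seen, a 5.7-fold lower number from compound 1 to compound 2 (0.76 log units; beyond the scatter) and a 3.4-fold higher number from compound 2 to compound 3 (0.53 log units; beyond the scatter), came from replacing the whole group on the ring nitrogen rather than the piece on the carbonyl carbon. On this basis the step from compound 3 to compound 4 is expected to be small, a 1.1-fold lower number from compound 3 to compound 4 (0.06 log units; within the scatter), with no clear direction. Compound 4 is therefore estimated at 500 nM in this assay, with a likely range from 180 nM to 1400 nM.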

Compound 4, half-maximal effective concentration: 150 nM
For compound 4 the middle estimate is 3.3-fold (0.52 log units) above the measured one, and the stated range ends above it.
By their numbers in this assay, from the lowest: compounds 4 and 2 (each within the scatter of the next); then compounds 3 and 1 (each within the scatter of the next).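

In this assay, among the compounds shown here, the piece on the carbonyl carbon proves able to move the number by itself, beyond the scatter (a 3.8-fold lower number from compound 3 to compound 4 (0.58 log units; beyond the scatter); a 6.5-fold lower number from compound 1 to compound 4 (0.81 log units; beyond the scatter)), whereas the only earlier step at this position stayed within it (a 1.7-fold lower number from compound 1 to compound 3 (0.23 log units; within the scatter)). Larger movements therefore no longer depend on replacing the whole group on the ring nitrogen, and (piperidin-4-yl)carbonyl and (3-cyanophenyl)sulfonyl on that nitrogen cannot be told apart (a 1.1-fold lower number from compound 2 to compound 4 (0.05 log units; within the scatter)). Nothing measured here accounts for the step from the 3-carboxypropyl chain to the piperidin-4-yl ring.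

The change brings in a ring and a ring nitrogen and removes a carboxylic acid all at once, so the compounds shown do not separate these parts. On these data alone, how a cyclohexyl ring or an open-chain amine on the same carbonyl carbon would compare remains open.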